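Isopropoxy in place of dimethylamino on the shared core

The source may report more compounds than this note shows. Statements on the series, on what has been measured and on what is new or still open speak of the compounds shown alone.

In a functional assay on NCI-H727 cells (Homo sapiens) for antiproliferative activity, with a stated time of 48 h (a lower number here means a stronger inhibitor, a higher number a weaker inhibitor), compound 1 `CCOC(=O)c1ccc(-c2ccc(N(CC)CC)nn2)cc1` gives 1500 nM as its half-maximal inhibitory concentration. Compound 2 `CCOC(=O)c1ccc(-c2ccc(N(C)C)nn2)cc1` reports only a limit, > 25000 nM in this read-out. Compound 3 `COC(=O)c1ccc(-c2ccc(N(C)C)nn2)cc1` also reports only a limit, > 25000 nM in the same read-out. Compound 4 `CCOC(=O)c1ccc(-c2ccc(OC(C)C)nn2)cc1` differs from compound 2 by isopropoxy in place of dimethylamino on an aromatic carbon with isopropoxy in place of dimethylamino on an aromatic carbon. Going by the values given here, the one step bearing on this place is the large at least 16-fold higher number from compound 1 to compound 2 (1.22 log units; beyond the scatter) and it involves the same amino group, whereas a step that the two limits leave unreadable from compound 2 to compound 3 concerns another place. Because an at least 16-fold higher number from compound 1 to compound 2 (1.22 log units; beyond the scatter) was large, a sizeable fall in the number is expected here. The expected change is an at least 3.5-fold lower number from compound 2 to compound 4 (0.55 log units; beyond the scatter) as estimated. For compound 4 the estimate is 7000 nM with an expected range from 1500 nM to 25000 nM in this assay overall.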

Compound 4, half-maximal inhibitory concentration: > 25000 nM
Compound 4: only a limit was reported; the forecaster's own chance of this, stated with the estimate: 35%; middle value at least 3.5-fold (0.55 log units) away from the limit.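

In this assay, compound 4 reports only a limit, > 25000 nM. Isopropoxy in place of diethylamino gives an at least 16-fold higher number from compound 1 to compound 4 (1.22 log units; beyond the scatter), so at this position the ether, like dimethylamino, gives no measured value, and among the groups shown here only diethylamino, in compound 1, does. The step from compound 2 to compound 4 cannot be read, so dimethylamino and isopropoxy cannot be ordered: the limit of > 25000 nM in this assay, at which 3 of the 4 values shown sit.

As far as these compounds go, whether a longer amine such as dipropylamino, or a ring amine such as pyrrolidine, would match or pass diethylamino remains open.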